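Methoxymethyl in place of methoxycarbonyl: a step still unmeasured

The compounds below may be only part of what the source reports. "The series", "measured", "known", "first", "only" and "open" are said of these compounds alone.

Among the measured compounds shown here, compound 1 `COC(=O)c1c(C)coc1-c1ccc2c(c1OC)CCCC2(C)C` is one of only two compounds measured so far in a functional assay on ZR-75-1 cells (Homo sapiens) for cytotoxicity, read by sulforhodamine B assay, with a stated time of 3 days; on this read-out higher numbers stand for an effect only at larger amounts of compound and lower numbers for an effect already at smaller amounts. In that test compound 1 gives 34.5 uM, and compound 2 `Cc1coc(-c2ccc3c(c2O)CCC3)c1C(=O)O` gives 30.2 uM. These two numbers lie within the usual scatter of each other, so neither stands apart.

Compound 3 `COCc1c(C)coc1-c1ccc2c(c1OC)CCCC2(C)C` keeps the core of compound 1 and carries methoxymethyl in place of methoxycarbonyl on an aromatic carbon. For the measured compounds named here, no measured pair isolates this change, so the data give no direct size for it. Going by the values given here, the only guide is that compound 1 at 34.5 uM and compound 2 at 30.2 uM show no gap beyond the scatter, although they differ in more than one place. The expected step of a 1.2-fold lower number from compound 1 to compound 3 (0.06 log units; within the scatter) is estimated to stay within the scatter, with no firm direction. Compound 3 is expected at 30 uM, with an estimated range from 12 uM to 70 uM.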

Compound 3, concentration for half-maximal effect: 14.3 uM
Compound 3: the middle estimate sits 2.1-fold (0.32 log units) above what was measured; low and high end bracket the measured number.
By their numbers in this assay, from the lowest: compound 3; then compounds 2 and 1 (each within the scatter of the next).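

Replacing methoxycarbonyl with methoxymethyl on an aromatic carbon of the five-membered aromatic ring with 1 oxygen gives, in this assay, a 2.4-fold lower number from compound 1 to compound 3 (0.38 log units; beyond the scatter). Among the compounds shown here, this is the first change seen at a single place, and it shows that this position is not indifferent to the group it carries: the effect now appears at smaller amounts of compound, by a modest step that clears the scatter. The change swaps 4 heavy atoms for 3 and removes the double bond outside aromatic rings, but no measurement available explains the step or ties it to either difference.

From the compounds shown here alone, it remains open how a smaller hydroxymethyl group or a longer ethoxymethyl chain would behave at this position. A basic aminomethyl group is equally untested here, so one step cannot yet show a trend.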